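The source may report more compounds than this note shows. Statements on the series, on what has been measured and on what is new or still open speak of the compounds shown alone.

Measured compounds and their values in a functional assay on MCF7 cells (Homo sapiens) for antiproliferative activity, read by sulforhodamine B assay, with a stated time of 48 h; on this read-out lower numbers stand for stronger inhibition of growth and higher numbers for weaker inhibition of growth:

- compound 1, `O=C(NCc1cn(Cc2ccc(F)cc2)nn1)c1cn(-c2ccccc2)nc1-c1ccccc1`: compound 1 gives 7000 nM
- compound 2, `O=C(NCc1cn(Cc2ccc(Cl)cc2)nn1)c1cn(-c2ccccc2)nc1-c1ccccc1`: compound 2 reaches only the limit of the assay, > 100000 nM, which is not a number
- compound 3, `O=C(NCc1cn(Cc2ccc(F)cc2)nn1)c1cn(-c2ccccc2)nc1-c1ccc(Cl)cc1`: compound 3 gives 570 nM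

Compound 1 and compound 3 share a core and differ in one place: chloro in place of hydrogen on an aromatic carbon. This change gave a 12-fold lower number from compound 1 to compound 3 (1.09 log units; beyond the scatter), so compound 3 has the lowest number of the two measured numbers.

Compound 1 and compound 2 differ by chloro in place of fluoro on an aromatic carbon. This change gave an at least 14-fold higher number from compound 1 to compound 2 (1.15 log units; beyond the scatter), and the step ends at a limit, (the limit of > 100000 nM in this assay, at which 1 of the 3 values shown sits), so its true size can only be said to be at least that large.

Compound 4, `O=C(NCc1cn(Cc2ccc(Cl)cc2)nn1)c1cn(-c2ccccc2)nc1-c1ccc(Cl)cc1`, has not yet been measured. It differs from compound 3 by chloro in place of fluoro on an aromatic carbon, which is the same change as that from compound 1 to compound 2, made on the same kind of place. If the change carries over, the step is expected to be a 21-fold higher number from compound 3 to compound 4 (1.32 log units; beyond the scatter), resting on the step from compound 1 to compound 2, an at least 14-fold higher number from compound 1 to compound 2 (1.15 log units; beyond the scatter), applied to compound 3 with its value of 570 nM. Compound 4 is therefore estimated at 12000 nM, with a likely range from 3000 nM to 100000 nM.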

Compound 4, concentration for 50% growth inhibition: 28800 nM
For compound 4 the middle estimate is 2.4-fold (0.38 log units) below the measured one, within the range that was stated.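

In this assay, the change from 4-fluorobenzyl to 4-chlorobenzyl gave a 51-fold higher number from compound 3 to compound 4 (1.70 log units; beyond the scatter), so on both cores that carry it this swap goes with weaker inhibition of growth: the same change on two cores in this assay, an at least 14-fold higher number (1.15 log units; beyond the scatter) from compound 1 to compound 2 and a 51-fold higher number (1.70 log units; beyond the scatter) from compound 3 to compound 4; the limit leaves it open whether they differ

Chloro in place of hydrogen on the other aromatic ring also kept its direction, with an at least 3.4-fold lower number from compound 2 to compound 4 (0.54 log units; beyond the scatter), so on both cores that change goes with stronger inhibition of growth: the same change on two cores in this assay, a 12-fold lower number (1.09 log units; beyond the scatter) from compound 1 to compound 3 and an at least 3.4-fold lower number (0.54 log units; beyond the scatter) from compound 2 to compound 4; the limit leaves it open whether they differ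

Compound 2 stands at a limit and not at a number, so the direction of each change carries over between these two cores, but whether its size does stays unknown: the limit of > 100000 nM in this assay, at which 1 of the 4 values shown sits.

The compounds shown leave open how a group other than fluoro or chloro would behave at this place, such as bromo, methoxy, trifluoromethyl or a plain hydrogen, and so whether the sharp loss belongs to chloro alone. They also leave open whether the same two changes keep their direction on a core with a different group in place of the phenyl on the nitrogen, such as a methyl or a longer chain.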